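Swapping the Amide Substituent on a Fatty Acid Receptor Agonist

The compounds below may be only part of what the source reports. "The series", "measured", "known", "first", "only" and "open" are said of these compounds alone.

Compound 3 `CC(C)NC(=O)CCc1ccc(NCc2cccc(Oc3ccccc3)c2)cc1` carries an isopropylcarbamoyl group on its chain, and in a functional assay on CHO cells for agonist activity at Free fatty acid receptor 1 (Homo sapiens), read by a luciferase reporter (a higher number here means a larger maximal response, a lower number a smaller maximal response), compound 3 gives 66%. Among the three measured compounds it stands second highest: compound 1 `O=C(O)CCCc1ccc(NCc2cccc(Oc3ccccc3)c2)cc1` gives 59%, and compound 2 `O=C(O)COc1ccc(NCc2cccc(Oc3ccccc3)c2)cc1` gives 84%. The step of a number 7 percentage points higher from compound 1 to compound 3 (within the scatter) lies within the scatter, whereas a number 18 percentage points lower from compound 2 to compound 3 (beyond the scatter) is a modest drop. Compound 4 `O=C(CCc1ccc(NCc2cccc(Oc3ccccc3)c2)cc1)N1CCCC1` differs from compound 3 in one place: pyrrolidin-1-yl in place of isopropylamino on a carbonyl carbon. For the measured compounds named here, none of the measured steps touches the group on the carbonyl carbon, so the nearest guide is a number 7 percentage points higher from compound 1 to compound 3 (within the scatter), where putting isopropylcarbamoyl in place of carboxymethyl changed little. With the amide kept and only the group on its carbonyl carbon exchanged, no step beyond the scatter is expected. Compound 4 is therefore estimated at 62%, within a range from 45% to 80%. This corresponds to an expected step of a number 4 percentage points lower from compound 3 to compound 4 (within the scatter).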

Compound 4, largest response reached (reported as percent of maximum), in percent of the reference or control that the assay uses: 46%
Compound 4: the middle estimate sits 16 percentage points above what was measured; the range from low to high includes it.
By their numbers in this assay, from the lowest: compound 4; then compounds 1 and 3 (each within the scatter of the next); then compound 2.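

Exchanging isopropylamino for pyrrolidin-1-yl on the carbonyl carbon gives a number 20 percentage points lower from compound 3 to compound 4 (beyond the scatter) in this assay and shows that the group at this position affects the maximal response. The (pyrrolidin-1-yl)carbonyl compound also sits lower than both carboxylic acids, with a number 13 percentage points lower from compound 1 to compound 4 (beyond the scatter) and a number 38 percentage points lower from compound 2 to compound 4 (beyond the scatter) on record, whereas the isopropylcarbamoyl amide of compound 3 stayed within the scatter of compound 1. No available measurement explains why the response falls with this swap.

The swap removes the amide hydrogen and adds a five-membered ring at once, so the data cannot say which of these changes matters. A dimethylamino group, with no amide hydrogen and no ring, and a cyclopentylamino group, with both, would separate the two.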